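The source may hold more compounds than are shown below. What is called first, only, known or untested is meant among the compounds shown, and "the series" means these compounds.

Measured compounds:
compound 1 `Nc1cc(N)c2nc(-c3ccccc3)c(Oc3ccc(Cl)c(Cl)c3)nc2c1`: < 100000 nM
compound 2 `Nc1cc(N)c2nc(-c3ccccc3)c(NCc3ccc(Cl)c(Cl)c3)nc2c1`: 66100 nM
compound 3 `CCOC(=O)[C@H](CCC(=O)O)NC(=O)c1ccc(Sc2nc3cc(N)cc(N)c3nc2-c2ccccc2)cc1`: < 100000 nM

In a functional assay on COLO 205 cells (Homo sapiens) for inhibition, read by sulforhodamine B assay, with a stated time of 48 h (a lower number here means that less compound is tolerated, a higher number that more compound is tolerated), compound 1 gives only a limit, < 100000 nM, not a number. Compound 3 likewise gives only a limit, < 100000 nM. Within the data shown here, compound 2 is the one compound with an actual number in this assay, 66100 nM. So compound 1 stands at the limit of < 100000 nM in this assay, at which 2 of the 3 values shown sit, and nothing shows how far below that limit it really lies.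

Compound 4 `Nc1cc(N)c2nc(-c3ccccc3)c(Sc3ccc(F)cc3)nc2c1` differs from compound 1 by (4-fluorophenyl)sulfanyl in place of 3,4-dichlorophenoxy on an aromatic carbon. Among the measured compounds shown here, no step between two measured compounds isolates this kind of change, and the three values known are all weak and close to one another, so for the move from compound 1 to compound 4 no step beyond the usual scatter is expected in this assay, in either direction: a step that the limit leaves unreadable from compound 1 to compound 4 is the expected step. For compound 4 the expected value in this assay is therefore 50000 nM, with a range from 15000 nM to 150000 nM.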

Compound 4, concentration lethal to 50% of the cells: < 100000 nM
Compound 4 was reported as a limit (the forecaster's own chance of this, stated with the estimate: 40%); the middle value lies beyond the limit too.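

Compound 1 and compound 4 are both reported only as limits, so no step between them can be read in this assay: the limit of < 100000 nM in this assay, at which 3 of the 4 values shown sit.

The compounds shown leave open how far each lies past its limit, and whether (4-fluorophenyl)sulfanyl in place of 3,4-dichlorophenoxy changes the value at all.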